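The source may hold more compounds than are shown below. What is called first, only, known or untested is meant among the compounds shown, and "the series" means these compounds.

Working notes on the series.

Compound 2 `Nc1nc(C(F)(F)F)cc2c1[nH]c(=O)n2Cc1ccc(NCc2ccccc2)nc1` carries a benzylamino group on the shared core. In an in vitro ADME assay on microsomes from liver (Homo sapiens) for pharmacokinetics (a higher number here means faster removal of the compound, a lower number slower removal), compound 2 gives only a limit, < 8 mL.min-1.g-1, and not a number. Compound 1 `CN(C)CCN1CCN(c2ccc(Cn3c(=O)[nH]c4c(N)nc(C(F)(F)F)cc43)cn2)CC1` is the other measured member of the series. In this assay compound 1 likewise gives only a limit, < 8 mL.min-1.g-1. For the measured compounds named here, the single measured step, a step that the two limits leave unreadable from compound 1 to compound 2, is therefore not readable in size, because both values sit at the limit (the limit of < 8 mL.min-1.g-1 in this assay, at which 2 of the 2 values shown sit).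

Compound 3 `CN(C)CCN(C)c1ccc(Cn2c(=O)[nH]c3c(N)nc(C(F)(F)F)cc32)cn1` is not yet measured. It differs from compound 2 by (2-(dimethylamino)ethyl)(methyl)amino in place of benzylamino on an aromatic carbon. The group that enters resembles the side chain of compound 1 in carrying a dimethylaminoethyl tail. Going by the values given here, nothing measured in this assay separates compound 1 from compound 2, so no direction for the step from compound 2 to compound 3 can be read; the only expectation is that compound 3 stays in the same region as both measured compounds. The expected step is a step that the limit leaves unreadable from compound 2 to compound 3, within the scatter. Compound 3 is therefore expected to give about 6 mL.min-1.g-1, with a range from 3 mL.min-1.g-1 to 15 mL.min-1.g-1, and most likely again only a limit.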

Compound 3, intrinsic clearance in microsomes: 16 mL.min-1.g-1
Estimate against measurement, compound 3: 2.7-fold (0.43 log units) below; measured number above the stated range.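

Working notes, continued. At this position, on an aromatic carbon next to the ring nitrogen, the open-chain (2-(dimethylamino)ethyl)(methyl)amino group gives the first result in this assay that clears the limit, with an at least 2.0-fold higher number from compound 2 to compound 3 (0.30 log units; that floor lies within the scatter) and an at least 2.0-fold higher number from compound 1 to compound 3 (0.30 log units; that floor lies within the scatter). Compound 1 carries a dimethylaminoethyl tail as well and still gives only a limit, < 8 mL.min-1.g-1, so that tail alone does not separate the compounds shown; the difference from compound 3 lies in the rest of the group, the piperazine ring against the open chain with its methyl on nitrogen. Both steps remain floors with no readable size, and neither can be called beyond the scatter, because the values of compound 1 and compound 2 are limits and not numbers: the limit of < 8 mL.min-1.g-1 in this assay, at which 2 of the 3 values shown sit.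

Going by these compounds, the true size of either step remains open, as does the order between compound 1 and compound 2. The compounds shown also leave open whether the higher number follows the terminal dimethylamine or the open chain, a question that a morpholine ring or a simple methoxyethyl chain at this position would bear on.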